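Aminomethyl swap on the hydroxy side of the series

The source may hold more compounds than are shown below. What is called first, only, known or untested is meant among the compounds shown, and "the series" means these compounds.

Measured in a functional assay on HL-60 cells (Homo sapiens) for inhibition, read by MTT assay, with a stated time of 48 h, tested at 10 uM; a higher number here means more inhibition of growth at the concentration tested, a lower number less inhibition of growth:
- compound 1 `Cc1cc(=O)c2c(O)cc(O)c([C@H]3CCN(C)C[C@H]3OC(=O)c3ccco3)c2o1`: 22%
- compound 2 `CCN(CC)Cc1c(O)c([C@H]2CCN(C)C[C@H]2O)c2oc(C)cc(=O)c2c1O`: 47%

Compound 2, at 47% of inhibition, stands highest of the two numbers, and compound 1 lies lower by a gap beyond the scatter. Compound 3 `Cc1cc(=O)c2c(O)c(CN3CCCC3)c(O)c([C@H]3CCN(C)C[C@H]3O)c2o1` carries pyrrolidin-1-yl in place of diethylamino on a saturated chain carbon bound to an aromatic carbon. No measured step sizes this kind of change, so no direction can be argued, and no shift beyond the scatter is expected in this assay. The expected change is a number 2 percentage points lower from compound 2 to compound 3 (within the scatter) as a rough estimate. Compound 3 is expected at 45% within an estimated range of 25% to 68% in this assay.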

Compound 3, percent growth inhibition at one concentration: 38%
The estimate for compound 3 lay 7 percentage points above the measured number; measured number inside the range.
By their numbers in this assay, from the lowest: compound 1; then compounds 3 and 2 (each within the scatter of the next).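

In this assay, within the data shown here, pyrrolidin-1-yl in place of diethylamino on a saturated chain carbon bound to an aromatic carbon gives a number 9 percentage points lower from compound 2 to compound 3 (within the scatter) and so offers the first sized step at this place: the ring form of the amine and the open diethylamino read alike here. The heavy-atom count is the same on both sides of the step. Nothing at hand explains this result or ties it to a property of either group.

Still open, as far as these compounds go, is whether piperidin-1-yl or morpholin-4-yl at the same place would shift the number beyond the scatter.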